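Swapping fluoro for acetyl on a shared benzoxazole-free core

The source may hold more compounds than are shown below. What is called first, only, known or untested is meant among the compounds shown, and "the series" means these compounds.

The series shares one core, a methylpiperazine attached to a fused bicyclic system, and differs only in the substituent on its carbon ring. Compound 1 `CN1CCN(c2nc3cc([N+](=O)[O-])ccc3o2)CC1` carries a nitro group and in a functional assay on ileum (strain Hartley) for agonist activity at 5-hydroxytryptamine receptor 3A (Cavia porcellus) (a lower number here means a less potent compound, a higher number a more potent compound, by a factor of ten per unit of this negative logarithm), compound 1 gives 6.1. Compound 2 `CN1CCN(c2nc3cc(F)ccc3o2)CC1` carries fluoro at the same place; in this assay compound 2 gives 5.57. Compound 3 `CN1CCN(c2nc3cc(Cl)cc(Cl)c3o2)CC1` bears two chloro groups and in this assay compound 3 gives 6.51. Within the data shown here, compound 2 therefore stands lowest of the three numbers, with compound 1 its nearest neighbour and compound 3 the furthest; the one single-point step among them, a number 0.53 log units lower from compound 1 to compound 2 (beyond the scatter), lies beyond the scatter.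

Compound 4 `CC(=O)c1ccc2oc(N3CCN(C)CC3)nc2c1` is the next single-point change from compound 2: acetyl in place of fluoro on an aromatic carbon. Among the measured compounds shown here, only the step from compound 1 to compound 2 bears on this move, since both concern the same position and the same departing group. That step was a modest loss on going to fluoro, so reversing it by putting another group with one hydrogen-bond acceptor in place of fluoro is expected to bring a modest rise, a number 0.43 log units higher from compound 2 to compound 4 (beyond the scatter). Compound 4 is accordingly estimated at 6, within a range from 5.4 to 6.6.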

Compound 4, negative logarithm of the half-maximal effective concentration: < 4
Compound 4: no number, only a limit (the forecaster's own chance of this, stated with the estimate: 5%); middle value at least 2.00 log units from the limit.
By their numbers in this assay, from the lowest: compound 2; then compound 1; then compound 3. At a limit, below all of these: compound 4.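

Compound 4 gives only a limit in this assay, not a number, so how far it truly falls remains unknown: the limit of < 4 in this assay, at which 1 of the 4 values shown sits.

Even so, this place on the six-membered aromatic ring proves far less forgiving than the earlier compounds suggested, with acetyl in place of fluoro giving a number at least 1.57 log units lower from compound 2 to compound 4 (beyond the scatter) and acetyl in place of nitro giving a number at least 2.10 log units lower from compound 1 to compound 4 (beyond the scatter). Among these compounds, both steps are large, whereas the one earlier change at this place, a number 0.53 log units lower from compound 1 to compound 2 (beyond the scatter), was modest, so the read-out here depends much more strongly on the group present than that single step could show.

The compounds shown do not separate the contribution of the carbonyl from that of the methyl in acetyl, and the entry of a hydrogen-bond acceptor cannot be distinguished from the entry of more heavy atoms. A methoxy group, a nitrile or an amine at this same place would be needed to tell whether the collapse belongs to acetyl alone or extends to other groups.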